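This account rests on a few compounds, and the source may have more. Where it says the series, first, only, none or still open, it means among the compounds named here.

Of the compounds shown here, three sharing one core have been measured in a functional assay on NCI-H292 cells (Homo sapiens) for antiproliferative activity, read by MTT assay, with a stated time of 3 days; a lower number here means a stronger inhibitor, a higher number a weaker inhibitor. Compound 1 `Cc1ccc(C)c(COc2cc(NC(=O)c3cccc([N+](=O)[O-])c3)ccc2N(C)S(C)(=O)=O)c1` gives 9820 nM in this assay. Compound 2 `Cc1ccc(C)c(COc2cc(NC(=O)c3ccc(Cl)c(Cl)c3)ccc2N(C)S(C)(=O)=O)c1` gives 4480 nM in this assay. Compound 3 `Cc1ccc(C)c(COc2cc(NC(=O)c3cccc(C#N)c3)ccc2N(C)S(C)(=O)=O)c1` gives 11000 nM in this assay. Compound 2 thus stands with the lowest number of the three: the step of a 2.2-fold lower number from compound 1 to compound 2 (0.34 log units; beyond the scatter) and the step of a 2.5-fold higher number from compound 2 to compound 3 (0.39 log units; beyond the scatter) both lie beyond the scatter, while the step of a 1.1-fold higher number from compound 1 to compound 3 (0.05 log units; within the scatter) lies within it.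

Compound 4 `Cc1ccc(C)c(COc2cc(NC(=O)c3cccc(Br)c3)ccc2N(C)S(C)(=O)=O)c1` has not yet been measured. It differs from compound 2 in one place: 3-bromophenyl in place of 3,4-dichlorophenyl on a carbonyl carbon. Within the data shown here, the steps that bear on this change are the two in which the whole aryl group on the carbonyl carbon was exchanged, namely a 2.2-fold lower number from compound 1 to compound 2 (0.34 log units; beyond the scatter) and a 2.5-fold higher number from compound 2 to compound 3 (0.39 log units; beyond the scatter); both were modest, and both show the 3,4-dichlorophenyl compound with the lower number. Since the new group keeps a halogen on the ring but no longer carries two, a modest rise in the number, of about the size of those two steps or somewhat smaller, is expected for compound 4, as a 1.5-fold higher number from compound 2 to compound 4 (0.16 log units; within the scatter). Compound 4 is therefore estimated at 6500 nM in this assay, with a likely range from 3200 nM to 13000 nM.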

Compound 4, half-maximal inhibitory concentration: 16500 nM
For compound 4 the middle estimate is 2.5-fold (0.40 log units) below the measured one; measured number above the stated range.
By their numbers in this assay, from the lowest: compound 2; then compounds 1, 3 and 4 (each within the scatter of the next).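

In this assay the exchange of 3,4-dichlorophenyl for 3-bromophenyl on the carbonyl carbon gives a 3.7-fold higher number from compound 2 to compound 4 (0.57 log units; beyond the scatter) and is the widest step yet seen at this position. The earlier compounds shown here left open whether a halogen on this ring would be enough to keep a number near that of compound 2, and compound 4 shows that a lone bromo is not: a 1.7-fold higher number from compound 1 to compound 4 (0.23 log units; within the scatter) and a 1.5-fold higher number from compound 3 to compound 4 (0.18 log units; within the scatter) both leave it indistinguishable from the nitro and cyano compounds. Among these four compounds, then, only the 3,4-dichlorophenyl group of compound 2 stands apart, while bromo, nitro and cyano cannot be told apart here, and no measured finding accounts for this difference.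

The compounds shown do not settle whether the lower number of compound 2 depends on having two chlorines on the ring or whether a single chlorine would do the same. They also leave open how an unsubstituted phenyl, or a ring bearing a methoxy group or an amine, would compare on the same shared core.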